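This account rests on a few compounds, and the source may have more. Where it says the series, first, only, none or still open, it means among the compounds named here.

Of the compounds shown here, three of a shared series have been measured in a functional assay on a cell-free system (plasma, Homo sapiens), with a stated time of 3 min (on this read-out higher numbers stand for weaker inhibition and lower numbers for stronger inhibition), and a fourth awaits a number. Compound 3 `CC(C)(C)C[C@@H](O)C(=O)N1OCC[C@H]1C(=O)NCc1cc(Cl)ccc1-n1cnnn1` gives 1100 nM in this assay, and compound 1 `CC(C)(C)[C@@H](O)C(=O)N1OCC[C@H]1C(=O)NCc1cc(Cl)ccc1-n1cnnn1`, which carries tert-butyl in place of neopentyl on a saturated chain carbon bound to a carbonyl carbon and an oxygen on a saturated carbon, gives 1600 nM. That step, a 1.5-fold higher number from compound 3 to compound 1 (0.16 log units; within the scatter), is a small one. Compound 2 `CC(C)(C)C[C@@H](O)C(=O)N1CC[C@@H]2C[C@@]21C(=O)NCc1cc(Cl)ccc1-n1cnnn1` is built on a different core; the difference between the two cores is not broken down here. In this assay compound 2 gives 620 nM, a number that lies within the scatter of compound 3 but beyond it from compound 1.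

Compound 4 `CC(C)(C)[C@@H](O)C(=O)N1CC[C@@H]2C[C@@]21C(=O)NCc1cc(Cl)ccc1-n1cnnn1` has not yet been measured. It stands to compound 2 as compound 1 stands to compound 3, because it carries tert-butyl in place of neopentyl on a saturated chain carbon bound to a carbonyl carbon and an oxygen on a saturated carbon, the same change at the same place. Among the compounds with values here, since the one observed instance of this change produced a 1.5-fold higher number from compound 3 to compound 1 (0.16 log units; within the scatter), the expected step is a 1.4-fold higher number from compound 2 to compound 4 (0.15 log units; within the scatter), resting on that single pair alone. Compound 4 is therefore estimated at 870 nM in this assay, with a likely range from 450 nM to 1700 nM.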

Compound 4, half-maximal inhibitory concentration: 1500 nM
Estimate against measurement, compound 4: 1.7-fold (0.24 log units) below; measured number inside the range.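

In this assay, tert-butyl in place of neopentyl on the core of compound 2 gives a 2.4-fold higher number from compound 2 to compound 4 (0.38 log units; beyond the scatter), a modest step that lies beyond the scatter, whereas the same change on the core of compound 3 stayed within it. Even so, the two steps cannot be told apart, so these data give no ground for saying that the core alters the effect of this change: the same change on two cores in this assay, a 1.5-fold higher number (0.16 log units; within the scatter) from compound 3 to compound 1 and a 2.4-fold higher number (0.38 log units; beyond the scatter) from compound 2 to compound 4, 1.7-fold (0.22 log units) apart, within the scatter of two such steps. Within the data shown here, this shows only that the change can be carried between these two cores with a broadly comparable outcome; with just two pairs, it does not show that the step is constant, that it truly differs between the cores, or that it would hold on any further core.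

The compounds shown leave open how a longer chain or a cyclohexyl group would compare with neopentyl and tert-butyl at this place on either core. They also leave open what an amine would do in place of the hydroxyl on that chain carbon.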